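A few compounds are considered here, and "the series" means these few. Any claim that something is new, unique, unknown or untested is made for them only; others in the source may bear on it.

In a functional assay on HO8910 cells (Homo sapiens) for cytotoxicity, read by CCK-8 assay, with a stated time of 24 h (on this read-out lower numbers stand for stronger inhibition and higher numbers for weaker inhibition), compound 1 `C/C(=C\c1cc(-c2cccnc2)co1)C(N)=O` gives 8640 nM. Compound 2 `C/C(=C\c1cc(-c2ccc(C)nc2)co1)C(N)=O` reaches only the limit of this assay, > 50000 nM. The change methyl in place of hydrogen on an aromatic carbon thus produces an at least 5.7-fold higher number from compound 1 to compound 2 (0.76 log units; beyond the scatter), a step known only as a bound due to the limit of > 50000 nM in this assay, at which 1 of the 3 values shown sits. Compound 3 `C/C(=C\c1nc(-c2ccccc2)cs1)C(N)=O` gives 3780 nM in this assay, the lower of the two numbers; the difference between its core and the core of compound 1 is not broken down here. Compound 4 `C/C(=C\c1nc(-c2ccc(C)cc2)cs1)C(N)=O` carries the same kind of change as compound 2, (methyl in place of hydrogen on an aromatic carbon), but here on a six-membered aromatic ring of carbon only, whereas in compound 2 it sits on a six-membered aromatic ring with 1 nitrogen, next to the ring nitrogen. Compound 4 is expected to show a weakening, a 2.4-fold higher number from compound 3 to compound 4 (0.38 log units; beyond the scatter), resting on an at least 5.7-fold higher number from compound 1 to compound 2 (0.76 log units; beyond the scatter) while the different ring leaves room for a smaller step. Compound 4 is estimated at 9000 nM, between 2500 nM and 40000 nM.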

Compound 4, half-maximal inhibitory concentration: > 50000 nM
Compound 4: no number, only a limit; the forecaster's own chance of this, stated with the estimate: 15%; middle value at least 5.5-fold (0.74 log units) away from the limit.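

In this assay compound 4 gives only a limit, > 50000 nM. Methyl in place of hydrogen on an aromatic carbon gives an at least 13-fold higher number from compound 3 to compound 4 (1.12 log units; beyond the scatter), so the change weakens inhibition on both cores shown: the same change on two cores in this assay, an at least 5.7-fold higher number (0.76 log units; beyond the scatter) from compound 1 to compound 2 and an at least 13-fold higher number (1.12 log units; beyond the scatter) from compound 3 to compound 4; the limit leaves it open whether they differ This shows a shared direction on two cores, but it gives no size that can be carried from one core to the other, as both steps are only bounds: the limit of > 50000 nM in this assay, at which 2 of the 4 values shown sit.

Still open, from the compounds shown here alone, is whether a group other than methyl at the same place, such as fluorine, methoxy or an amine, would be tolerated on either core. Also open, going by these compounds, is whether the primary amide could give way to a carboxylic acid.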